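The compounds below may be only part of what the source reports. "The series", "measured", "known", "first", "only" and "open" are said of these compounds alone.

Compound 1, `O=C1/C(=C/c2cn(-c3ccccc3)nc2-c2cccs2)SC(=S)N1C1CCS(=O)(=O)C1`: 117000 nM
Compound 2, `CCN1C(=O)/C(=C/c2ccccc2)SC1=S`: > 200000 nM
Compound 3, `CCN1C(=O)/C(=C/c2ccccc2O)SC1=S`: > 200000 nM

In an assay for inhibition of LL-diaminopimelate aminotransferase, chloroplastic (Arabidopsis thaliana) (a higher number here means a weaker inhibitor, a lower number a stronger inhibitor), compound 1 gives 117000 nM. For compound 2 the assay reports only a limit, > 200000 nM. For compound 3 it likewise reports only a limit, > 200000 nM. Compound 3 thus stands at the limit of > 200000 nM in this assay, at which 2 of the 3 values shown sit. The step that the two limits leave unreadable from compound 2 to compound 3 cannot be sized from these two limits. Compound 4, `CCN1C(=O)/C(=C/c2cc(Cc3ccccc3Cl)ccc2O)SC1=S`, differs from compound 3 by 2-chlorobenzyl in place of hydrogen on an aromatic carbon. Going by the values given here, no measured step covers this change; the one numerical value, that of compound 1, shows only that a compound with more groups on the shared core can be read in this assay. Compound 4 is therefore estimated at 150000 nM, between 50000 nM and 600000 nM, which is an expected step of an at least 1.3-fold lower number from compound 3 to compound 4 (0.12 log units; that floor lies within the scatter) that the limit on compound 3 leaves uncertain.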

Compound 4, half-maximal inhibitory concentration: 46000 nM
The estimate for compound 4 lay 3.3-fold (0.51 log units) above the measured number, outside the stated range (below it).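

Placing 2-chlorobenzyl on the aromatic carbon para to a hydroxy group gives, in this assay, an at least 4.3-fold lower number from compound 3 to compound 4 (0.63 log units; beyond the scatter). Going by these compounds alone, this is the first step with a readable size, and it shows that this carbon can carry a large ring-bearing group with stronger inhibition as the result. Only a lower bound on the step can be given: the limit of > 200000 nM in this assay, at which 2 of the 4 values shown sit.

It remains open whether the chlorine matters, since plain benzyl is not among the compounds shown. Going by these compounds, whether a smaller group, such as methyl, or an amine at this carbon would do the same also remains unknown.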